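This account rests on a few compounds, and the source may have more. Where it says the series, first, only, none or still open, it means among the compounds named here.

Measured compounds:
compound 1, `Nc1scc(CN2CCN(c3ccc(F)cc3Cl)CC2)c1C(=O)c1ccc(Cl)cc1`: 0%
compound 2, `Nc1scc(CN2CCN(c3ccc([N+](=O)[O-])cc3)CC2)c1C(=O)c1ccc(Cl)cc1`: 1%

In an assay on CHO cells for displacement of a labelled ligand from adenosine receptor A1 (Homo sapiens), read by scintillation counting, with a stated time of 120 min, tested at 10 uM (on this read-out higher numbers stand for more inhibition at the one concentration tested (going by the name of the read-out) and lower numbers for less inhibition), compound 1 gives 0%. In this assay compound 2 gives 1%. Compound 2 holds the higher of the two numbers, but the step of a number 1 percentage points higher from compound 1 to compound 2 (within the scatter) lies within the scatter, so the two compounds are not told apart by these data; both show essentially no inhibition at the single concentration tested.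

Compound 3, `Nc1scc(CN2CCN(c3ccc(Cl)c(C(F)(F)F)c3)CC2)c1C(=O)c1ccc(Cl)cc1`, differs from compound 2 in one place: 4-chloro-3-(trifluoromethyl)phenyl in place of 4-nitrophenyl on an amine nitrogen in a ring. Within the data shown here, the only measured step that bears on this change is the swap of the aryl group on an amine nitrogen in a ring, which gave a number 1 percentage points higher from compound 1 to compound 2 (within the scatter). Among the measured compounds shown here, that step was small, and both compounds measured so far sit near zero, so a different aryl group in the same place is expected to leave the read-out where it is. The expected step is therefore a number 1 percentage points higher from compound 2 to compound 3 (within the scatter), with no change beyond the scatter. Compound 3 is estimated to give 2% in this assay, with a range from -8% to 14%.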

Compound 3, a percentage reported as inhibition, at one concentration (the size of the read-out at that concentration, not a potency): 0%
Compound 3: middle estimate off by 2 percentage points, on the high side, and the stated range covers the measured number.
By their numbers in this assay, from the lowest: compounds 1, 3 and 2 (each within the scatter of the next).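

In this assay, the change at this position gives a number 1 percentage points lower from compound 2 to compound 3 (within the scatter), and the same entering group in place of 2-chloro-4-fluorophenyl gives no change at the digits printed from compound 1 to compound 3 (within the scatter). Among these compounds, the earlier pair showed only that one swap of aryl groups on this amine nitrogen in a ring left the number within the scatter; now three different substituted phenyl groups cannot be told apart, even though 4-chloro-3-(trifluoromethyl)phenyl has 11 heavy atoms and 0 hydrogen-bond acceptors where 4-nitrophenyl has 9 heavy atoms and 2 hydrogen-bond acceptors. No measurement at hand accounts for this flat result.

The compounds shown leave open whether a group other than a substituted phenyl on that ring nitrogen, such as a benzyl group, a pyridine ring or a simple methyl, would move the number. They also leave open whether a change elsewhere on the shared core, such as an amide in place of the ketone carbonyl, would give any measurable inhibition in this assay.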